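Compound 3: losing the phenylcarbamoyl group

A few compounds are considered here, and "the series" means these few. Any claim that something is new, unique, unknown or untested is made for them only; others in the source may bear on it.

In a physicochemical assay for lipophilicity, using the shake flask method, in phosphate buffer, measured as octanol-water partition, with a stated time of 30 min, at pH 7.4 (a lower number here means a more polar compound, a higher number a more lipophilic compound), compound 1 (`O=C(Nc1ccccc1)c1cnc(NCc2c(F)ccc3c2CCO3)n2cnnc12`) gives 4.1 as the higher of two measured numbers. Compound 2 (`O=C1CCCN1c1cnc(NCc2c(F)ccc3c2CCO3)c2cn[nH]c(=O)c12`) gives 1.8 on its own core. The gap between these two numbers lies beyond the scatter. Compound 3 (`CC1(C)CC(=O)N(c2cnc(NCc3c(F)ccc4c3CCO4)n3cnnc23)C1`) keeps the core of compound 1 and carries 4,4-dimethyl-2-oxopyrrolidin-1-yl in place of phenylcarbamoyl on an aromatic carbon, so the six-membered aromatic ring of carbon only leaves. Among the compounds with values here, no measured pair isolates this change. A downward move beyond the scatter in this assay is expected, estimated as a number 1.10 log units lower from compound 1 to compound 3 (beyond the scatter) for this change. For compound 3 the estimated value is 3 with a range of 2.4 to 3.6 expected.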

Compound 3, distribution coefficient: 2
For compound 3 the middle estimate is 1.00 log units above the measured one, outside the stated range (below it).
By their numbers in this assay, from the lowest: compounds 2 and 3 (each within the scatter of the next); then compound 1.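

In this assay, placing 4,4-dimethyl-2-oxopyrrolidin-1-yl in place of phenylcarbamoyl on an aromatic carbon gives a number 2.10 log units lower from compound 1 to compound 3 (beyond the scatter), the first step read on a single core. This position therefore carries a large share of the number, with the rest of the core of compound 1 unchanged. Nothing at hand accounts for the size of this step. Open, as far as these compounds go, is whether the step follows the leaving six-membered aromatic ring of carbon only or the entering group. From the compounds shown here alone, how a carboxylic acid or a morpholine would stand on this aromatic carbon also remains open.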